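Solubility notes: alkyl variation on the ring amide nitrogen

This account rests on a few compounds, and the source may have more. Where it says the series, first, only, none or still open, it means among the compounds named here.

Measured compounds:
- compound 1 `C=CC(=O)N1CC[C@H](N2C(=O)N(C(C)C)Cc3cnc(Nc4ccc(N5CCN(C)CC5)cc4OC)nc32)C1`: 2490 ug/mL
- compound 2 `C=CC(=O)N1CC[C@H](N2C(=O)N(c3ccccc3)Cc3cnc(Nc4cccc(N5CCN(C)CC5)c4)nc32)C1`: 714 ug/mL
- compound 3 `C=CC(=O)NC1CCC(N2C(=O)N(Cc3ccccc3)Cc3cnc(Nc4ccc(N5CCN(C)CC5)cc4OC)nc32)CC1`: 18.8 ug/mL

In a physicochemical assay for solubility, read by HPLC, in phosphate buffer, measured as thermodynamic solubility, with a stated time of 24 h, at pH 6.8 (on this read-out lower numbers stand for lower solubility and higher numbers for higher solubility), compound 1 gives the highest number of the three. Compound 2 is the nearest to it and comes out lower, by a margin beyond the scatter of the measurement. Compound 3 is the furthest away, far lower and well beyond the scatter. No two of the measured compounds differ in only one place, so no single-point step can be read from the measured set; only the ordering of the three values is known.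

Compound 4 `C=CC(=O)N1CC[C@H](N2C(=O)N(C)Cc3cnc(Nc4ccc(N5CCN(C)CC5)cc4OC)nc32)C1` is the next compound in this assay. It differs from compound 1 as follows: methyl in place of isopropyl on an amide-type nitrogen in a ring. The change is confined to the alkyl group on that amide-type nitrogen, while the rest of the structure stays as in compound 1.

For this assay, the step from compound 1 to compound 4 is expected to be small, either none beyond the scatter or a modest upward one. The estimate is a 1.2-fold higher number from compound 1 to compound 4 (0.08 log units; within the scatter). On that basis compound 4 is expected to give about 3000 ug/mL, with a range from 1500 ug/mL to 6000 ug/mL.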

Compound 4, solubility: 1250 ug/mL
Estimate against measurement, compound 4: 2.4-fold (0.38 log units) above, outside the stated range (below it).
By their numbers in this assay, from the lowest: compound 3; then compounds 2, 4 and 1 (each within the scatter of the next, the first and the last beyond it).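

In this assay, going by these compounds alone, the one single-place step is a 2.0-fold lower number from compound 1 to compound 4 (0.30 log units; within the scatter), so methyl in place of isopropyl on this amide-type nitrogen stays inside the scatter of the measurement. Within the data shown here, this is the first direct reading at this position: on the core of compound 1, with the 1-(vinylcarbonyl)pyrrolidin-3-yl group unchanged, the two alkyl groups cannot be told apart in this read-out. Nothing shown offers an explanation for this result.

As far as these compounds go, whether the same holds for a longer chain, or for a chain ending in an amine or a carboxylic acid on that nitrogen, remains open. Compound 2 and compound 3 differ from compound 1 in more than one place, so the effect of a phenyl or benzyl group at this position also cannot be read from them.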